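Aryl swap on the amide carbonyl: outlook for compound 3

The source may report more compounds than this note shows. Statements on the series, on what has been measured and on what is new or still open speak of the compounds shown alone.

Of the compounds shown here, two have been measured in an assay on isolated protein for inhibition of Rho-associated protein kinase 2 (Homo sapiens), read by scintillation counting, radiometric assay and 33P incorporation, with a stated time of 40 min, in the presence of a further agent that is not named here; on this read-out lower numbers stand for stronger inhibition and higher numbers for weaker inhibition. Compound 1 `Cc1nc(C(=O)Nc2cccc(NC(=O)COc3ccc4c(=O)ccoc4c3)c2)cs1` gives 33 nM. Compound 2 `Nc1cccc(C(=O)Nc2cccc(NC(=O)COc3ccc4c(=O)ccoc4c3)c2)c1` gives 58 nM; the only measured step, a 1.8-fold higher number from compound 1 to compound 2 (0.24 log units; within the scatter), leaves the two within the scatter, so compound 2 stands level with compound 1 on the numbers shown and neither is separated from the other.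

Compound 3 `O=C(COc1ccc2c(=O)ccoc2c1)Nc1cccc(NC(=O)c2ccc(C(=O)O)cc2)c1` differs from compound 2 by 4-carboxyphenyl in place of 3-aminophenyl on a carbonyl carbon. Within the data shown here, no measured step covers this exchange; the single step available, a 1.8-fold higher number from compound 1 to compound 2 (0.24 log units; within the scatter), exchanged a different aryl group on the same carbonyl carbon and stayed within the scatter. On that basis the expected step of a 1.2-fold higher number from compound 2 to compound 3 (0.08 log units; within the scatter) is small, with no direction claimed beyond the scatter, though the data for this particular exchange are absent. Compound 3 is therefore estimated at 70 nM in this assay, between 25 nM and 200 nM.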

Compound 3, half-maximal inhibitory concentration: 2030 nM
Compound 3: the middle estimate sits 29-fold (1.46 log units) below what was measured; measured number above the stated range.
By their numbers in this assay, from the lowest: compounds 1 and 2 (each within the scatter of the next); then compound 3.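

The aryl group on this carbonyl carbon is not freely exchangeable in this assay: 4-carboxyphenyl in place of 3-aminophenyl gives a 35-fold higher number from compound 2 to compound 3 (1.54 log units; beyond the scatter), and 4-carboxyphenyl in place of 2-methyl-1,3-thiazol-4-yl gives a 62-fold higher number from compound 1 to compound 3 (1.79 log units; beyond the scatter). The earlier exchange at this place stayed within the scatter, so the position accepts 3-aminophenyl and 2-methyl-1,3-thiazol-4-yl alike, while among the three groups shown only 4-carboxyphenyl stands apart. No evidence at hand bears on what lies behind these steps.

The compounds shown leave open whether the steps go with the carboxylic acid itself or with the arrangement named in 4-carboxyphenyl; 3-carboxyphenyl and 4-aminophenyl on the same carbonyl carbon would separate the two. The methyl ester of compound 3 would show whether the free carboxylic acid is needed for the step.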